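A few compounds are considered here, and "the series" means these few. Any claim that something is new, unique, unknown or untested is made for them only; others in the source may bear on it.

Of the compounds shown here, two from this series have been measured in a functional assay on A549 cells (Homo sapiens) for cytotoxicity, read by MTT assay, with a stated time of 72 h; a higher number here means a weaker inhibitor, a lower number a stronger inhibitor. Compound 1 `COc1cccc(/C=C2\CCC/C(=C\c3cc(OC)c(OC)c(OC)c3)C2=O)c1OC` gives 5900 nM in this assay. Compound 2 `COc1ccc(/C=C2\CCC/C(=C\c3cccc(Cl)c3)C2=O)cc1OC` gives 11000 nM in this assay, and this number and that of compound 1 lie within the usual scatter of each other, so the two compounds cannot be told apart on these data. Compound 3 `COc1ccc(/C=C2\CCC/C(=C\c3ccc(Cl)cc3Cl)C2=O)cc1OC` has not yet been measured. It differs from compound 2 in one place: 2,4-dichlorophenyl in place of 3-chlorophenyl on a double-bonded chain carbon bound to a double-bonded ring carbon. Among the compounds with values here, no measured pair shows the effect of such a change, so the two values at hand give no guide to its size. Compound 3 is expected to sit near compound 2, with a step of a 1.2-fold lower number from compound 2 to compound 3 (0.09 log units; within the scatter) that stays within the scatter. The estimate for compound 3 in this assay is 9000 nM, with a range from 3000 nM to 30000 nM.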

Compound 3, half-maximal inhibitory concentration: > 20000 nM
Compound 3 was reported as a limit; the forecaster's own chance of this, stated with the estimate: 10%; middle value at least 2.2-fold (0.34 log units) from the limit.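

This gives the series its first readable step at this place, on a double-bonded chain carbon bound to a double-bonded ring carbon: replacing 3-chlorophenyl with 2,4-dichlorophenyl gives an at least 1.8-fold higher number from compound 2 to compound 3 (0.25 log units; that floor lies within the scatter). The change therefore brings no gain in this assay, although the floor of the step does not establish a real loss. Compound 3 gives > 20000 nM, which is a limit and not a number, and the full size of the step cannot be read because of that limit: the limit of > 20000 nM in this assay, at which 1 of the 3 values shown sits.

The compounds shown leave open whether the count of chlorine atoms or their arrangement on the ring governs this step, as the change alters both at once. They also leave open how a phenyl ring carrying an amine or a carboxylic acid in place of chlorine would read at this place.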